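This account rests on a few compounds, and the source may have more. Where it says the series, first, only, none or still open, it means among the compounds named here.

Going by the values given here, compound 1 `NCCNc1cc(N2CCN(c3ccc(Cl)cc3)CC2)nc2ccccc12` gives 6600 nM in an ADME assay on HEp-2 cells (Homo sapiens) for cytotoxicity, read by CCK-8 assay, with a stated time of 6 days (on this read-out lower numbers stand for higher toxicity in this test and higher numbers for lower toxicity in this test), and it is the only plain number in the set. Compound 2 `NCCNc1cc(N2CCN(C(=O)C3(c4ccccc4)CCCC3)CC2)nc2ccccc12` reaches only a limit of the assay in this assay, > 100000 nM. Compound 3 `NCCNc1cc(N2CCN(C(=O)C3(c4ccccc4)CCC3)CC2)nc2ccccc12` likewise stops at a limit of the assay, > 100000 nM. Among the compounds with values here, the one step between neighbours, a step that the two limits leave unreadable from compound 2 to compound 3, cannot be sized, since both of its values rest at the limit of > 100000 nM in this assay, at which 2 of the 3 values shown sit. Compound 4 `NCCNc1cc(N2CCN(c3ccccc3)CC2)nc2ccccc12` differs from compound 1 by hydrogen in place of chloro on an aromatic carbon, the same change read one bond further out being 4-chlorophenyl to phenyl. Within the data shown here, no measured step touches this part of the molecule: the only step shown sits on the carbonyl side chain of compound 2 and compound 3 and is unreadable, so the expectation for compound 4 rests on compound 1 alone. Compound 4 is therefore expected to show a step within the scatter, a 1.5-fold higher number from compound 1 to compound 4 (0.18 log units; within the scatter), in this assay. The estimate for compound 4 is 10000 nM, with a range from 3500 nM to 30000 nM.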

Compound 4, half-maximal cytotoxic concentration: 20800 nM
For compound 4 the middle estimate is 2.1-fold (0.32 log units) below the measured one, and the stated range covers the measured number.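

In this assay, going by these compounds alone, hydrogen in place of chloro on the aromatic carbon gives a 3.2-fold higher number from compound 1 to compound 4 (0.50 log units; beyond the scatter), the first step in the set that can be read, whereas the step on the carbonyl side chain cannot be read. The single chlorine atom of the 4-chlorophenyl group is thus enough on its own to move the number towards lower toxicity in this test, with the rest of the molecule unchanged. Nothing measured here gives a cause for this step.

The compounds shown leave open whether fluoro, methyl or methoxy on this same carbon would give a number closer to that of compound 1 or that of compound 4. They also leave open whether a chlorine on another carbon of the ring would have the same effect.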